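The compounds below may be only part of what the source reports. "The series", "measured", "known", "first", "only" and "open" are said of these compounds alone.

In a functional assay on A549 cells (Homo sapiens) for cytotoxicity, read by MTT assay, with a stated time of 48 h (on this read-out higher numbers stand for weaker inhibition and lower numbers for stronger inhibition), the measured compounds are:
compound 1 `CCOC(=O)c1c(-c2c(Cl)c3ccccc3oc2=O)nn(-c2ccccc2)c1C(=O)OCC`, which gives 34000 nM;
compound 2 `CCOC(=O)c1c(-c2c(Cl)c3ccccc3oc2=O)nn(-c2ccc(OC)cc2)c1C(=O)OCC`, which gives 18000 nM;
compound 3 `CCOC(=O)c1c(-c2cc3ccccc3oc2=O)nn(-c2ccccc2)c1C(=O)OCC`, which gives 100000 nM.

Compound 3 has the highest number of the three and is thus the weakest here; its nearest neighbour is compound 1, and the step between them, a 2.9-fold higher number from compound 1 to compound 3 (0.47 log units; beyond the scatter), lies beyond the scatter, as does its gap to compound 2.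

Compound 4 `CCOC(=O)c1c(-c2cc3ccccc3oc2=O)nn(-c2ccc(C)c(C)c2)c1C(=O)OCC` differs from compound 3 by 3,4-dimethylphenyl in place of phenyl on an aromatic nitrogen. For the measured compounds named here, the only measured step that touches this same phenyl is a 1.9-fold lower number from compound 1 to compound 2 (0.28 log units; within the scatter), which stayed within the scatter. Going by the values given here, no methyl-bearing analogue has been measured. Only a small step, if any, is therefore expected: a 1.4-fold lower number from compound 3 to compound 4 (0.15 log units; within the scatter). Compound 4 is estimated at 70000 nM, within a range from 30000 nM to 160000 nM.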

Compound 4, half-maximal inhibitory concentration: 52000 nM
Beside the measured number, compound 4's estimate is 1.3-fold (0.13 log units) above it; low and high end bracket the measured number.
By their numbers in this assay, from the lowest: compounds 2, 1, 4 and 3 (each within the scatter of the next, the first and the last beyond it).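

With the chloro absent from the core, 3,4-dimethylphenyl in place of phenyl on the aromatic nitrogen gives a 1.9-fold lower number from compound 3 to compound 4 (0.28 log units; within the scatter) in this assay. A purely carbon addition to this phenyl thus stays within the scatter, just as the methoxy step did in the chloro-bearing pair, so two different substituents on this ring have now left the number within the scatter. No evidence on the reason is available.

On these data alone, whether an amine or a carboxylic acid on this phenyl would move the number beyond the scatter remains open. So does whether 3,4-dimethylphenyl would behave the same way on the chloro-bearing core of compound 1.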